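This account rests on a few compounds, and the source may have more. Where it says the series, first, only, none or still open, it means among the compounds named here.

Compound 1 `COc1cccc(/C=C/C(=O)c2sc(Nc3cccc(C)c3)nc2C)c1` gives in a functional assay on BGC-823 cells (Homo sapiens) for cytotoxicity, read by MTT assay (a lower number here means a stronger inhibitor, a higher number a weaker inhibitor), only a limit of the assay, > 25000 nM. Compound 2 `Cc1ccccc1Nc1nc(C)c(C(=O)/C=C/c2ccccc2)s1` gives in this assay also only a limit, > 25000 nM. Compound 3 `Cc1cccc(Nc2nc(C)c(C(=O)/C=C/c3ccccc3)s2)c1` gives in this assay 13600 nM.

The cores of compound 2 and compound 3 differ by 2-methylphenyl in place of 3-methylphenyl on a nitrogen on an aromatic ring, a step of an at least 1.8-fold lower number from compound 2 to compound 3 (0.26 log units; that floor lies within the scatter). From compound 3 to compound 1 the change is methoxy in place of hydrogen on an aromatic carbon, which gave an at least 1.8-fold higher number from compound 3 to compound 1 (0.26 log units; that floor lies within the scatter). Compound 4 `COc1cccc(/C=C/C(=O)c2sc(Nc3ccccc3C)nc2C)c1` carries the same change on the core of compound 2, namely (methoxy in place of hydrogen on an aromatic carbon). Because compound 2 already sits at the limit of > 25000 nM in this assay, at which 2 of the 3 values shown sit, and because the earlier step of an at least 1.8-fold higher number from compound 3 to compound 1 (0.26 log units; that floor lies within the scatter) went toward weaker inhibition, compound 4 is expected to stay at or beyond that limit, an expected step that the limit leaves unreadable from compound 2 to compound 4. The estimate for compound 4 is therefore 45000 nM, between 20000 nM and 120000 nM.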

Compound 4, half-maximal inhibitory concentration: > 25000 nM
Compound 4 was reported as a limit; the forecaster's own chance of this, stated with the estimate: 85%; the middle value does not contradict the limit.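

Compound 4, like compound 1 and compound 2, is reported only as a limit, so no step from compound 2 or compound 1 to compound 4 can be read: the limit of > 25000 nM in this assay, at which 3 of the 4 values shown sit.

On these data alone, whether methoxy in place of hydrogen changes anything on the core of compound 2 stays open.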